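The source may report more compounds than this note shows. Statements on the series, on what has been measured and on what is new or still open speak of the compounds shown alone.

The measured compounds:

compound 1, `CCCNC(=O)c1ccc(Oc2nc(-c3c(C)noc3C)cnc2N)cc1`, 17500 nM
compound 2, `Cc1noc(C)c1-c1cnc(N)c(Oc2ccc(C(=O)NC3CCCCC3)cc2)n1`, 21600 nM

Both were measured in a functional assay on LoVo cells (Homo sapiens) for inhibition, read by MTT assay, with a stated time of 72 h; on this read-out lower numbers stand for stronger inhibition and higher numbers for weaker inhibition. Compound 2 has the highest of the two numbers, but its nearest neighbour, compound 1, is within the scatter: a 1.2-fold higher number from compound 1 to compound 2 (0.09 log units; within the scatter). Compound 3, `Cc1noc(C)c1-c1cnc(N)c(Oc2ccc(C(=O)Nc3ccccc3)cc2)n1`, is not yet measured. It differs from compound 2 by phenyl in place of cyclohexyl on an amide-type nitrogen. For the measured compounds named here, the only measured step that bears on this position is the one just given, which changed the group on the amide-type nitrogen from propyl to cyclohexyl and stayed within the scatter. On that basis the account expects the change to phenyl to produce no step beyond the scatter, so that the step from compound 2 to compound 3 is estimated at a 1.1-fold lower number from compound 2 to compound 3 (0.06 log units; within the scatter). For compound 3 in this assay the estimate is 19000 nM, with a range from 7000 nM to 50000 nM.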

Compound 3, half-maximal inhibitory concentration: 5740 nM
For compound 3 the middle estimate is 3.3-fold (0.52 log units) above the measured one, and the stated range ends above it.
By their numbers in this assay, from the lowest: compound 3; then compounds 1 and 2 (each within the scatter of the next).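

In this assay the group on the amide-type nitrogen can matter: phenyl in place of cyclohexyl gives a 3.8-fold lower number from compound 2 to compound 3 (0.58 log units; beyond the scatter), and phenyl in place of propyl gives a 3.0-fold lower number from compound 1 to compound 3 (0.48 log units; beyond the scatter), whereas the earlier change from propyl to cyclohexyl stayed within the scatter. Cyclohexyl and phenyl have the same count of 6 carbon heavy atoms and differ in that one ring is aromatic and the other is not, so the size of the group by atom count does not account for this step. Nothing available here gives a reason for the stronger inhibition seen with phenyl.

The compounds shown leave open whether the step belongs to the phenyl ring itself or would persist with a benzyl group or a pyridine ring on the same nitrogen. They also do not tell how a fluorine or methoxy substituent on the phenyl would change the number.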